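This account rests on a few compounds, and the source may have more. Where it says the series, first, only, none or still open, it means among the compounds named here.

Compound 1 `CCCn1c(=O)c2nc(-c3cnn(Cc4cc(C(F)(F)F)ccc4Cl)c3)[nH]c2n(CCC)c1=O` carries the shared core with a pyrazole linked through a saturated chain carbon to a substituted phenyl ring. Within the data shown here, in an in vitro assay on HEK293 cells for displacement of a labelled ligand from adenosine receptor A2b (Homo sapiens) (a higher number here means a weaker inhibitor, a lower number a stronger inhibitor), compound 1 gives 22 nM, the lowest of the two numbers so far. Compound 2 `CCCn1c(=O)c2nc(-c3cc(C)nn3C)[nH]c2n(CCC)c1=O` gives 3700 nM, a gap beyond the scatter. Compound 3 `CCCn1c(=O)c2c(nc(-n3cccn3)n2Cc2ccccc2)n(CCC)c1=O` reaches only a limit of this assay, > 5800 nM, and so stands outside the ranked values (the limit of > 5800 nM in this assay, at which 1 of the 3 values shown sits).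

Compound 4 `CCCn1c(=O)c2nc(-c3cnn(Cc4cccc(F)c4F)c3)[nH]c2n(CCC)c1=O` differs from compound 1 in one place: 2,3-difluorophenyl in place of 2-chloro-5-(trifluoromethyl)phenyl on a saturated chain carbon bound to an aromatic nitrogen. Among the measured compounds shown here, no measured pair shows this exchange, so the step is only expected; a modest weakening, within or near the scatter, is assumed, with the estimated step being a 2.7-fold higher number from compound 1 to compound 4 (0.44 log units; beyond the scatter). For compound 4 the expected value is 60 nM, between 15 nM and 250 nM.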

Compound 4, inhibition constant: 240 nM
Compound 4: middle estimate off by 4.0-fold (0.60 log units), on the low side; the measured number falls inside the stated range.
By their numbers in this assay, from the lowest: compound 1; then compound 4; then compound 2. At a limit, above all of these: compound 3.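

In this assay the aryl group on a saturated chain carbon bound to an aromatic nitrogen is a sensitive place: 2,3-difluorophenyl in place of 2-chloro-5-(trifluoromethyl)phenyl gives an 11-fold higher number from compound 1 to compound 4 (1.04 log units; beyond the scatter). Among these compounds, this is the first single-place step, and it shows that a change on the phenyl ring alone, with the rest of the structure held, can move the number by a large step. Nothing measured here bears on the cause of this step.

From the compounds shown here alone, how the chlorine and the trifluoromethyl each contribute stays open, since both leave together and two fluorines enter. Going by these compounds, how a nitrile or a methoxy group on this phenyl ring would read in this assay also stays open.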